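The source may report more compounds than this note shows. Statements on the series, on what has been measured and on what is new or still open speak of the compounds shown alone.

Series notes. Of the compounds shown here, two of this set have numbers so far. Compound 1 `CC(=O)Oc1ccccc1C(=O)NCC[Se]C#N` gives 2100 nM in a functional assay on PANC-1 cells (Homo sapiens) for antiproliferative activity, read by MTT assay, with a stated time of 48 h; a lower number here means a stronger inhibitor, a higher number a weaker inhibitor. Among the measured compounds shown here, compound 2 `CC(=O)Oc1ccccc1C(=O)OCC[Se]C#N` gives 36100 nM in this assay, which is the highest of the two numbers; the only measured step, a 17-fold higher number from compound 1 to compound 2 (1.24 log units; beyond the scatter), shows that what sits on the carbonyl carbon attached to the aromatic ring moves the read-out by a large margin.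

Compound 3 `CC(=O)Oc1ccccc1C(=O)[Se]CC[Se]C#N` is the next member. Relative to compound 2 it carries a group of 6 heavy atoms (3 carbon, 1 nitrogen, 2 selenium; no ring) in place of a group of 6 heavy atoms (3 carbon, 1 nitrogen, 1 oxygen, 1 selenium; no ring), on a carbonyl carbon. For the measured compounds named here, no measured step covers the exchange of oxygen for selenium at this position; the one step that exists, from compound 1 to compound 2, only tells that this position is sensitive, not in which direction a second selenium would push. The expectation is therefore a modest move from the high number of compound 2, with wide uncertainty.

For compound 3 the estimate in this assay is 9000 nM, expected within 1500 nM to 50000 nM, a step of a 4.0-fold lower number from compound 2 to compound 3 (0.60 log units; beyond the scatter) being expected.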

Compound 3, half-maximal inhibitory concentration: 18900 nM
Beside the measured number, compound 3's estimate is 2.1-fold (0.32 log units) below it; measured number inside the range.
By their numbers in this assay, from the lowest: compound 1; then compounds 3 and 2 (each within the scatter of the next).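

Replacing the oxygen-containing group on the carbonyl carbon with the selenium-containing group gives a 1.9-fold lower number from compound 2 to compound 3 (0.28 log units; within the scatter) in this assay, so this exchange does not separate the two compounds. The amide of compound 1 remains apart from the selenium-containing group, with a 9.0-fold higher number from compound 1 to compound 3 (0.95 log units; beyond the scatter), and the sensitivity of this position now appears as a gap between compound 1 and both of the other compounds, not as a graded response across the three. No accompanying measurement explains that gap.

Still open, going by these compounds, is whether the nitrogen of the amide alone accounts for the gap, which a methyl group on that nitrogen or a sulfur atom in its place would test. A longer chain on the carbonyl carbon also remains to be placed against compound 1.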